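This account rests on a few compounds, and the source may have more. Where it says the series, first, only, none or still open, it means among the compounds named here.

Compound 1 `CN(C)CCn1cnnc1-c1cc(Oc2ccc(NC(=O)N/N=C/c3c[nH]c4ccccc34)cc2F)ccn1` carries a 1H-indol-3-yl group on a carbon with a double bond to nitrogen. In a functional assay on A549 cells (Homo sapiens) for cytotoxicity, read by MTT assay, with a stated time of 72 h (a lower number here means a stronger inhibitor, a higher number a weaker inhibitor), compound 1 gives 820 nM. Two analogues replace that group with a substituted phenyl. Compound 3 `CN(C)CCn1cnnc1-c1cc(Oc2ccc(NC(=O)N/N=C/c3ccc(O)c(F)c3)cc2F)ccn1` carries a 3-fluoro-4-hydroxyphenyl there, and in this assay compound 3 gives 13400 nM. Compound 2 `COc1cc(/C=N/NC(=O)Nc2ccc(Oc3ccnc(-c4nncn4CCN(C)C)c3)c(F)c2)cc(OC)c1OC` carries a 3,4,5-trimethoxyphenyl, and in this assay compound 2 gives > 100000 nM, which is the limit of > 100000 nM in this assay, at which 1 of the 3 values shown sits, and so a limit rather than a number. Of the two numbers, compound 1 holds the lowest. Both replacements cost potency: there was a 16-fold higher number from compound 1 to compound 3 (1.21 log units; beyond the scatter) and an at least 120-fold higher number from compound 1 to compound 2 (2.08 log units; beyond the scatter).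

Compound 4 `COc1ccc(/C=N/NC(=O)Nc2ccc(Oc3ccnc(-c4nncn4CCN(C)C)c3)c(F)c2)cc1O` is the untested member of the set. Its change from compound 1 is 3-hydroxy-4-methoxyphenyl in place of 1H-indol-3-yl on a carbon with a double bond to nitrogen. Both measured steps bear on this change, since each also swaps the indolyl for a substituted phenyl, and both were large in the direction of weaker inhibition. A large rise in this assay is therefore expected for compound 4, somewhere in the span marked out by compound 3 and compound 2. Compound 4 is expected to give about 20000 nM, with a range from 5000 nM to 100000 nM. The expected change is a 24-fold higher number from compound 1 to compound 4 (1.39 log units; beyond the scatter).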

Compound 4, half-maximal inhibitory concentration: > 100000 nM
Compound 4: no number, only a limit; the forecaster's own chance of this, stated with the estimate: 25%; at least 5.0-fold (0.69 log units) between middle value and limit.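

The value for compound 4 is a limit and not a number, the same limit that compound 2 reaches: the limit of > 100000 nM in this assay, at which 2 of the 4 values shown sit. This shows that the cost of removing the 1H-indol-3-yl depends strongly on which substituted phenyl takes its place on the carbon with a double bond to nitrogen: the 3-hydroxy-4-methoxyphenyl gives an at least 120-fold higher number from compound 1 to compound 4 (2.08 log units; beyond the scatter), while exchanging the 3-fluoro-4-hydroxyphenyl for it gives an at least 7.4-fold higher number from compound 3 to compound 4 (0.87 log units; beyond the scatter). Compound 3 and compound 4 each carry a hydroxy group on the phenyl, so having one does not by itself set the outcome among these compounds, and with compound 2 and compound 4 at the same limit, the step between them cannot be read.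

The compounds shown leave open whether the gain seen with compound 1 needs the hydrogen on the indole nitrogen, which a 1-methyl-1H-indol-3-yl group at this position would test. They also leave open whether the two-ring shape alone is enough, as a quinolin-3-yl group would show, or whether a single ring such as 4-aminophenyl could come close to compound 1.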